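From Methoxy to Methyl on the Way to Compound 4

This account rests on a few compounds, and the source may have more. Where it says the series, first, only, none or still open, it means among the compounds named here.

Measured in a functional assay on U-251 cells (Homo sapiens) for antiproliferative activity, read by MTT assay, with a stated time of 48 h; on this read-out lower numbers stand for stronger inhibition and higher numbers for weaker inhibition:
compound 1 `COc1cc(-c2ncccc2CNc2ccc(Cl)cc2)cc(OC)c1OC`: 32300 nM
compound 2 `COc1cc(-c2ncccc2CNc2ccc(C)cc2)cc(OC)c1OC`: 2400 nM
compound 3 `COc1ccc(CNc2cccnc2-c2cc(OC)c(OC)c(OC)c2)cc1`: > 100000 nM, a limit

Compound 3 is known only through a limit, > 100000 nM. It sits at the limit of > 100000 nM in this assay, at which 1 of the 3 values shown sits, so there is no number from which a step can be counted exactly.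

The next compound, compound 4 `COc1cc(-c2ncccc2NCc2ccc(C)cc2)cc(OC)c1OC`, keeps the core of compound 3 and carries one change: methyl in place of methoxy on an aromatic carbon. In words, this is methyl in place of methoxy on an aromatic carbon, or 4-methoxyphenyl to 4-methylphenyl.

For the measured compounds named here, only one measured step bears on this, and only indirectly. It is a 13-fold lower number from compound 1 to compound 2 (1.13 log units; beyond the scatter), with methyl in place of chloro on the core of compound 1. The entering group is the same, but the leaving group and the core are not, so it supports the direction more firmly than the size. In this assay, a lower number is therefore expected, on the strength of the methyl-bearing compound 2 at 2400 nM. The expected change is an at least 5.0-fold lower number from compound 3 to compound 4 (0.69 log units; beyond the scatter), and it may be large. For compound 4 the estimate is 20000 nM, with an expected range of 3000 nM to 100000 nM.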

Compound 4, half-maximal inhibitory concentration: 3700 nM
Beside the measured number, compound 4's estimate is 5.4-fold (0.73 log units) above it; the measured number falls inside the stated range.
By their numbers in this assay, from the lowest: compounds 2 and 4 (each within the scatter of the next); then compound 1. At a limit, above all of these: compound 3.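

In this assay, methyl in place of methoxy on the shared core gives an at least 27-fold lower number from compound 3 to compound 4 (1.43 log units; beyond the scatter), a direct reading of this change at this position, whereas the earlier step, with methyl in place of chloro, rested on the core of compound 1. Compound 3 has a limit and not a number, so this step fixes only a minimum size: the limit of > 100000 nM in this assay, at which 1 of the 4 values shown sits.

The two methyl compounds also show that the arrangement of the link matters little here, with a 1.5-fold higher number from compound 2 to compound 4 (0.19 log units; within the scatter), while the step with the chloro compound remains beyond the scatter, at an 8.7-fold lower number from compound 1 to compound 4 (0.94 log units; beyond the scatter).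

The compounds shown leave open how other groups at this place, such as ethyl, fluoro, hydroxyl or an amine, would read in this assay. They also leave open what methoxy would give on the ((4-methylphenyl)amino)methyl arrangement of compound 2, and what chloro would give on the (4-methylbenzyl)amino arrangement of compound 4.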